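A few compounds are considered here, and "the series" means these few. Any claim that something is new, unique, unknown or untested is made for them only; others in the source may bear on it.

Measured so far in a functional assay on HeLa cells (Homo sapiens) for inhibition, read by sulforhodamine B assay; on this read-out higher numbers stand for weaker inhibition and lower numbers for stronger inhibition:

- Compound 1, `O=C1C=C(NC2CCCC2)C(=O)c2c1nc1n2[C@H]2OC[C@@H](O)[C@H]2OC1`, gives > 16000 nM, which is a limit of this assay and not a number.
- Compound 2, `O=C1C(Nc2ccc(C(F)(F)F)cc2)=CC(=O)c2c1nc1n2[C@H]2OC[C@@H](O)[C@H]2OC1`, gives 8920 nM.

Among the compounds with values here, compound 2 thus holds the only number in this assay among the two compounds measured; the other value is a limit (the limit of > 16000 nM in this assay, at which 1 of the 2 values shown sits). Within the data shown here, no step between measured compounds differing in one place is available, so nothing indicates how a change on the amine nitrogen shifts the read-out.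

Compound 3, `O=C1C(Nc2cccc(F)c2)=CC(=O)c2c1nc1n2[C@H]2OC[C@@H](O)[C@H]2OC1`, is next to be measured. It differs from compound 2 by 3-fluorophenyl in place of 4-(trifluoromethyl)phenyl on an amine nitrogen. With only the value of compound 2 to go on, the step of a 1.2-fold higher number from compound 2 to compound 3 (0.09 log units; within the scatter) is expected to be small, at most around the scatter of repeated measurements and with no clear direction. Compound 3 is therefore estimated at 11000 nM, within 3500 nM to 35000 nM.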

Compound 3, half-maximal inhibitory concentration: > 8000 nM
Compound 3 was reported as a limit; the forecaster's own chance of this, stated with the estimate: 40%; the middle value does not contradict the limit.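

Compound 3 gives > 8000 nM, which is a limit of the assay and not a number. Within the data shown here, no step from compound 2 to compound 3 can therefore be read. The compounds shown leave open how 3-fluorophenyl in place of 4-(trifluoromethyl)phenyl on an amine nitrogen shifts the read-out.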